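A few compounds are considered here, and "the series" means these few. Any claim that something is new, unique, unknown or untested is made for them only; others in the source may bear on it.

Going by the values given here, compound 3, `COc1ccccc1-c1cn(C[C@H](O)[C@H]2OC(=O)C(OCc3ccccc3)=C2OCc2ccccc2)nn1`, is the one compound among the three measured that reaches only a limit in a functional assay on HeLa cells (Homo sapiens) for antiproliferative activity, read by MTT assay, with a stated time of 72 h; a lower number here means a stronger inhibitor, a higher number a weaker inhibitor: compound 3 gives > 100000 nM, which is a limit of the assay and not a number. By comparison, compound 1, `C[Si](C)(C)c1cn(C[C@H](O)[C@H]2OC(=O)C(OCc3ccccc3)=C2OCc2ccccc2)nn1`, gives 22300 nM in this assay, and compound 2, `COc1ccc(-c2cn(C[C@H](O)[C@H]3OC(=O)C(OCc4ccccc4)=C3OCc3ccccc3)nn2)cc1`, gives 16400 nM. The unmeasured compound 4, `Cc1ccc(-c2cn(C[C@H](O)[C@H]3OC(=O)C(OCc4ccccc4)=C3OCc3ccccc3)nn2)cc1`, differs from compound 3 by 4-methylphenyl in place of 2-methoxyphenyl on an aromatic carbon. The step that bears most directly on this change is an at least 6.0-fold higher number from compound 2 to compound 3 (0.78 log units; beyond the scatter), and an at least 4.4-fold higher number from compound 1 to compound 3 (0.65 log units; beyond the scatter) points in the same direction, while a 1.4-fold lower number from compound 1 to compound 2 (0.13 log units; within the scatter) shows the 4-methoxyphenyl compound alongside the silicon-bearing compound 1 without a step beyond the scatter. Compound 4 carries its substituent at the same position of the phenyl ring as compound 2 rather than compound 3, so the step in this assay is expected to run toward lower numbers, back in the region of compound 2. Compound 4 is therefore estimated to give 22000 nM in this assay, within a range from 8000 nM to 70000 nM, which corresponds to an expected step of an at least 4.5-fold lower number from compound 3 to compound 4 (0.65 log units; beyond the scatter).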

Compound 4, half-maximal inhibitory concentration: 25500 nM
The estimate for compound 4 lay 1.2-fold (0.06 log units) below the measured number, within the range that was stated.
By their numbers in this assay, from the lowest: compounds 2, 1 and 4 (each within the scatter of the next). At a limit, above all of these: compound 3.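

Going by these compounds alone, compound 3 remains the only one that gives no number, and its value is a limit of the assay: the limit of > 100000 nM in this assay, at which 1 of the 4 values shown sits. The change from 2-methoxyphenyl to 4-methylphenyl gives an at least 3.9-fold lower number from compound 3 to compound 4 (0.59 log units; beyond the scatter), a step beyond the scatter that is bounded by that limit, so a second compound besides compound 2 now stands clear of compound 3. In this assay, methyl in place of methoxy gives a 1.6-fold higher number from compound 2 to compound 4 (0.19 log units; within the scatter), and the 4-methylphenyl group in place of the silicon-bearing group gives a 1.1-fold higher number from compound 1 to compound 4 (0.06 log units; within the scatter), both within the scatter, so the methoxy group is not needed to keep the number in this region.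

The compounds shown leave open whether a 2-methylphenyl group would also reach the limit. They also leave open whether an amine or a carboxylic acid on the phenyl ring would move the number beyond the scatter.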